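Benzyl in place of methyl on the selenium of compound 1

This account rests on a few compounds, and the source may have more. Where it says the series, first, only, none or still open, it means among the compounds named here.

Measured compounds:
Compound 1 `C[Se]/C(=N\C(=O)c1cc2ccccc2s1)NC(=O)c1cc2ccccc2s1`: 34700 nM
Compound 2 `O=C(/N=C(/NC(=O)c1csc([N+](=O)[O-])c1)[Se]Cc1ccccc1)c1csc([N+](=O)[O-])c1`: 54100 nM

In an ADME assay on MCF-10A cells (Homo sapiens) for cytotoxicity, read by MTT assay, with a stated time of 72 h (on this read-out lower numbers stand for stronger inhibition of growth and higher numbers for weaker inhibition of growth), compound 1 gives 34700 nM, and compound 2 gives 54100 nM. These two numbers lie within the usual scatter of each other, so on the values at hand compound 1 cannot be set apart from compound 2; both show only weak inhibition of growth.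

Compound 3 `O=C(/N=C(/NC(=O)c1cc2ccccc2s1)[Se]Cc1ccccc1)c1cc2ccccc2s1` shares the core of compound 1 and differs from it in one place: phenyl in place of hydrogen on a saturated chain carbon bound to a selenium atom. For the measured compounds named here, compound 2 carries the same benzyl group on selenium but a different core, so no step between measured compounds isolates this change. With compound 1 and compound 2 so close, nothing in the data points to a shift beyond the scatter in either direction.

The step expected here is a 1.2-fold higher number from compound 1 to compound 3 (0.06 log units; within the scatter), essentially none. Compound 3 is therefore estimated at 40000 nM, expected between 15000 nM and 110000 nM.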

Compound 3, concentration for total growth inhibition: 62900 nM
Compound 3: middle estimate off by 1.6-fold (0.20 log units), on the low side, within the range that was stated.
By their numbers in this assay, from the lowest: compounds 1, 2 and 3 (each within the scatter of the next).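

For the compounds shown here, compound 1 and compound 3 share the core of compound 1 and differ only in methyl to benzyl, so this pair gives the first direct reading of a change at the saturated chain carbon bound to a selenium atom. In this assay the change gives a 1.8-fold higher number from compound 1 to compound 3 (0.26 log units; within the scatter), which means that a phenyl can take the place of a hydrogen here without a shift that can be told from the scatter. The data at hand offer no measurement that bears on this outcome.

Only methyl and benzyl are shown on the selenium with this core, so it remains open whether a longer chain, such as butyl, or a chain ending in an amine or a carboxylic acid, would stay in the same range. No step that changes the core alone can be read from the compounds shown.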